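The source may report more compounds than this note shows. Statements on the series, on what has been measured and on what is new or still open speak of the compounds shown alone.

Measured in a functional assay on LNCaP cells (Homo sapiens) for antiproliferative activity; a higher number here means a weaker inhibitor, a lower number a stronger inhibitor:
- compound 1 `Cn1ncc(Cl)c1-c1cc(C(=O)N[C@@H]2CN[C@H](CC(O)CO)C[C@H]2c2ccc(F)c(F)c2)oc1Cl`: 100 nM
- compound 2 `Cn1ncc(Cl)c1-c1cc(C(=O)N[C@@H]2CN[C@H](CC(O)CO)C[C@H]2c2ccc(Cl)c(Cl)c2)oc1Cl`: 70 nM
- compound 3 `Cn1ncc(Cl)c1-c1cc(C(=O)N[C@@H]2CN[C@H](CCCO)C[C@H]2c2ccc(Cl)c(Cl)c2)oc1Cl`: 210 nM

Compound 1 lies within the scatter of compound 2, as a 1.4-fold lower number from compound 1 to compound 2 (0.15 log units; within the scatter) shows, while compound 3 has the highest number of the set. Compound 4 `CC(=O)NCC[C@@H]1C[C@@H](c2ccc(F)c(F)c2)[C@H](NC(=O)c2cc(-c3c(Cl)cnn3C)c(Cl)o2)CN1` is unmeasured and has acetamidomethyl in place of 1,2-dihydroxyethyl on a saturated chain carbon bound to a saturated ring carbon. The aryl step does not bear on this change. The closest guide is the loss of hydroxy alone, a 3.0-fold higher number from compound 2 to compound 3 (0.48 log units; beyond the scatter), a modest step. Within the data shown here, no measured compound carries acetamidomethyl. A modest step towards a higher number is therefore expected in this assay, estimated as a 2.0-fold higher number from compound 1 to compound 4 (0.30 log units; within the scatter). For compound 4 the expected value is 200 nM, with an estimated range of 70 nM to 600 nM.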

Compound 4, half-maximal inhibitory concentration: 130 nM
Compound 4: middle estimate off by 1.5-fold (0.19 log units), on the high side; the measured number falls inside the stated range.
By their numbers in this assay, from the lowest: compounds 2, 1, 4 and 3 (each within the scatter of the next, the first and the last beyond it).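

In this assay, acetamidomethyl in place of 1,2-dihydroxyethyl gives a 1.3-fold higher number from compound 1 to compound 4 (0.11 log units; within the scatter). Among these compounds, the hydroxy groups are therefore not required at this position in the 3,4-difluorophenyl series: a chain carrying no hydroxy, with an amide instead, holds the number, which the single hydroxy loss in compound 3 could not show. No evidence is available to explain this result.

Still open, on these data alone, is whether an amine or a carboxylic acid in place of 1,2-dihydroxyethyl would hold the number as well. Also open, as far as these compounds go, is whether acetamidomethyl behaves the same alongside 3,4-dichlorophenyl.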